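The compounds below may be only part of what the source reports. "The series", "measured", "known", "first", "only" and "open" are said of these compounds alone.

Compound 1, `Cc1cccc(-c2nn(-c3ccc(F)cc3F)cc2CNCCN2CCN(C)CC2)c1`, was tested in an ADME assay on Huh-7 cells (Homo sapiens) for cytotoxicity; a higher number here means that more compound is tolerated, a lower number that less compound is tolerated. The result for compound 1 is a limit of the assay rather than a number: compound 1 gives > 20000 nM in this assay. Compound 2, `CCOC(=O)Cn1cc(CNCCN2CCN(C)CC2)c(-c2ccccc2C)n1`, was also measured in this assay, and here too the result is a limit: compound 2 gives > 20000 nM. Both values therefore sit at the same point, (the limit of > 20000 nM in this assay, at which 2 of the 2 values shown sit), so neither compound is placed relative to the other on the numbers shown, and compound 1 stands only at that limit.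

Compound 3, `CN1CCN(CCNCc2cn(-c3ccc(F)cc3F)nc2C(C)(C)C)CC1`, has not yet been measured in this assay. It differs from compound 1 in one place: tert-butyl in place of 3-methylphenyl on an aromatic carbon. Among the measured compounds shown here, no step between two measured compounds is available to gauge such a change. With both measured compounds at the limit, the step from compound 1 to compound 3 is expected to be none beyond the scatter, as a step that the limit leaves unreadable from compound 1 to compound 3. Compound 3 is thus estimated to give 30000 nM in this assay, within a range from 12000 nM to 80000 nM, most likely again reported only as a limit.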

Compound 3, half-maximal cytotoxic concentration: > 20000 nM
Compound 3: no number, only a limit; the forecaster's own chance of this, stated with the estimate: 80%; the middle value does not contradict the limit.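

In this assay compound 3 gives > 20000 nM as a limit of the assay and not a number. Compound 1 also stands only at a limit, so the change from 3-methylphenyl to tert-butyl between compound 1 and compound 3 cannot be read as a step. The compounds shown leave open how compound 1, compound 2 and compound 3 rank relative to one another: the limit of > 20000 nM in this assay, at which 3 of the 3 values shown sit.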